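The compounds below may be only part of what the source reports. "The series", "measured", "known", "first", "only" and "open" are said of these compounds alone.

Measured so far in a functional assay on cardiac atrium for agonist activity at histamine H2 receptor (Cavia porcellus); on this read-out lower numbers stand for smaller maximal responses and higher numbers for larger maximal responses:

compound 1, `N=C(NCCCc1c[nH]cn1)NC(=O)CC(c1ccc(F)c(F)c1)c1nccs1`: 90%
compound 2, `CC(CC(=O)NC(=N)NCCCc1c[nH]cn1)c1ccccn1`: 98%

Two compounds share the core; they differ at the branch carbon of the chain and in the aromatic group carried there. Compound 2 gives 98% in this assay, and compound 1 gives 90% in the same read-out. The gap between the two numbers lies within the usual scatter, so the pair shows no difference that can be read as real, and neither can be called the more effective of the two.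

The next compound, compound 3, `CC(CC(=O)NC(=N)NCCCc1c[nH]cn1)c1nccs1`, is not yet measured. It differs from compound 2 in one place:

1,3-thiazol-2-yl in place of pyridin-2-yl on a saturated chain carbon bound to two saturated chain carbons

Among the compounds with values here, no step between measured compounds covers this exchange. What the data do show is that compound 1, which also carries the 1,3-thiazol-2-yl group, gives 90%, and that compound 2 gives 98%: both numbers sit close together. On that basis the step of a number 5 percentage points lower from compound 2 to compound 3 (within the scatter) is expected to remain within the scatter, with no direction that can be named. For compound 3 the estimate in this assay is 93%, with a range from 80% to 102%.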

Compound 3, largest response reached (Emax), in percent of the reference or control that the assay uses: 91%
Estimate against measurement, compound 3: 2 percentage points above, within the range that was stated.
By their numbers in this assay, from the lowest: compounds 1, 3 and 2 (each within the scatter of the next).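

Notes on the series: in this assay, 1,3-thiazol-2-yl in place of pyridin-2-yl on a saturated chain carbon bound to two saturated chain carbons gives a number 7 percentage points lower from compound 2 to compound 3 (within the scatter), which is the first one-place reading of this ring exchange, and it does not separate the two rings. With 1,3-thiazol-2-yl kept in both compounds, methyl in place of 3,4-difluorophenyl on a saturated chain carbon bound to an aromatic carbon and a saturated chain carbon gives a number 1 percentage points higher from compound 1 to compound 3 (within the scatter), so this exchange does not separate them either, a reading that compound 1 and compound 2 could not give, as they differ in more than one place. No further data bear on either result.

As far as these compounds go, both exchanges keep an aromatic ring on this chain carbon, so it remains open whether a carboxylic acid or a primary amine there would still fall within the scatter in this assay. Also open, from the compounds shown here alone, is whether ethyl or a longer alkyl chain in place of methyl in compound 3 would leave the read-out equally unseparated.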